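Oxygen Enters the Fused Ring: Expectation for Compound 3

The source may hold more compounds than are shown below. What is called first, only, known or untested is meant among the compounds shown, and "the series" means these compounds.

Compound 1, `CC(=O)N[C@@H]1CCC[C@H](C(=O)Nc2cc(-c3cnn4c3CCCC4)ccn2)C1`: 2.4
Compound 2, `CC(=O)N[C@@H]1CCC[C@H](C(=O)Nc2cc(-c3cnc4n3CCCC4)c(Cl)cn2)C1`: 2.7

Both were measured in a physicochemical assay for lipophilicity, using the shake flask method, measured as octanol-water partition, at pH 7.4; on this read-out higher numbers stand for higher lipophilicity and lower numbers for lower lipophilicity. Compound 2 stands at the top of the two numbers, but compound 1 sits within the scatter of it, so the two cannot be separated. Compound 3, `CC(=O)N[C@@H]1CCC[C@H](C(=O)Nc2cc(-c3cnn4c3COCC4)c(Cl)cn2)C1`, is not yet measured; it differs from compound 2 by a group of 9 heavy atoms (6 carbon, 2 nitrogen, 1 oxygen; one five-membered aromatic ring with 2 hetero atoms, one six-membered non-aromatic ring with 2 hetero atoms) in place of a group of 9 heavy atoms (7 carbon, 2 nitrogen; one five-membered aromatic ring with 2 hetero atoms, one six-membered non-aromatic ring with 1 hetero atom), on an aromatic carbon. Within the data shown here, no step between measured compounds is available to size this change, so the expectation rests on the structure alone. The expected step is a number 0.70 log units lower from compound 2 to compound 3 (beyond the scatter), downward, of modest size and beyond the scatter. Compound 3 is estimated at 2, ranging from 1.4 to 2.6.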

Compound 3, distribution coefficient: 2.4
Compound 3: the middle estimate sits 0.40 log units below what was measured; low and high end bracket the measured number.
By their numbers in this assay, from the lowest: compounds 1, 3 and 2 (each within the scatter of the next).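

On the aromatic carbon ortho to the chloro group, the group with a six-membered non-aromatic ring with 2 hetero atoms, which brings one more hydrogen-bond acceptor, gives a number 0.30 log units lower from compound 2 to compound 3 (within the scatter) in this assay. At this position, then, the exchange leaves the two compounds inseparable on this read-out. No measurement bears on why this is so.

This single step cannot say how a ring nitrogen carrying an amine hydrogen in place of the oxygen would read at this carbon. From the compounds shown here alone, how an open chain such as methoxyethyl would read there also remains open.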